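The compounds below may be only part of what the source reports. "The series", "measured", "known", "first", "only" and "open" are said of these compounds alone.

Measured compounds:
Compound 1 `O=C(NCc1ccc(NC(=O)c2cc(-c3ccccc3)ccc2N2CCCC2)cc1)OCc1cccnc1` — in a functional assay on AGS cells (Homo sapiens) for inhibition, read by MTT assay, with a stated time of 72 h (on this read-out lower numbers stand for stronger inhibition and higher numbers for weaker inhibition), compound 1 gives only a limit of the assay, > 100000 nM.
Compound 2 `O=C(NCc1ccc(NC(=O)c2cccc(F)c2N2CCCC2)cc1)OCc1cccnc1` — in this assay compound 2 also gives only a limit of the assay, > 100000 nM.

Neither value is a true number, so compound 1 stands at the limit of > 100000 nM in this assay, at which 2 of the 2 values shown sit, with no measurable inhibition shown. Compound 3 `O=C(NCc1ccc(NC(=O)c2cc(Cl)ccc2N2CCCC2)cc1)OCc1cccnc1` differs from compound 1 by chloro in place of phenyl on an aromatic carbon. With both measured compounds sitting only at the limit, no step beyond the scatter is expected in either direction. Compound 3 is estimated at 150000 nM, within 50000 nM to 500000 nM. The expected step that the limit leaves unreadable from compound 1 to compound 3 amounts to no change beyond the scatter.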

Compound 3, half-maximal inhibitory concentration: > 100000 nM
Compound 3 gave a limit, no number; the forecaster's own chance of this, stated with the estimate: 85%; the middle value does not contradict the limit.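

Compound 1 and compound 3 both give only a limit, so no step between them can be read: the limit of > 100000 nM in this assay, at which 3 of the 3 values shown sit.

The compounds shown leave open whether any change to the shared core would give a true number in this assay.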